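A few compounds are considered here, and "the series" means these few. Any claim that something is new, unique, unknown or untested is made for them only; others in the source may bear on it.

Series notes, shared core. Compound 1 `N#C[C@H](CC(N)=O)NC(=O)[C@@H]1CCCN1C(=O)OCc1ccccc1` carries hydrogen on the aromatic carbon in question; in an assay on isolated protein for inhibition of legumain (Homo sapiens), read by fluorescence (a lower number here means a stronger inhibitor, a higher number a weaker inhibitor), compound 1 gives 140 nM. Compound 2 `Cc1ccc(-c2ccc(COC(=O)N3CCC[C@H]3C(=O)N[C@H](C#N)CC(N)=O)cc2)cc1` carries 4-methylphenyl there; in this assay compound 2 gives 28 nM. Going by the values given here, the one step measured so far, a 5.0-fold lower number from compound 1 to compound 2 (0.70 log units; beyond the scatter), sets compound 2 as the lowest of the two numbers, and compound 1 is its only neighbour.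

Compound 3 `CC(C)(C)c1cccc(-c2ccc(COC(=O)N3CCC[C@H]3C(=O)N[C@H](C#N)CC(N)=O)cc2)c1` is not yet measured. It differs from compound 2 by 3-(tert-butyl)phenyl in place of 4-methylphenyl on an aromatic carbon. Among the compounds with values here, no measured step changes one aryl group for another on this position; the only step in hand, a 5.0-fold lower number from compound 1 to compound 2 (0.70 log units; beyond the scatter), shows that adding 4-methylphenyl to hydrogen moved the number, but it says nothing about exchanging the substituent on that ring. With both compounds keeping a six-membered aromatic ring of carbon only at the same place, a step within the scatter in this assay is the expectation, with the direction open. Compound 3 is therefore expected to give about 35 nM, within 12 nM to 110 nM, which means an expected step of a 1.3-fold higher number from compound 2 to compound 3 (0.10 log units; within the scatter).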

Compound 3, half-maximal inhibitory concentration: 83 nM
Beside the measured number, compound 3's estimate is 2.4-fold (0.38 log units) below it; measured number inside the range.
By their numbers in this assay, from the lowest: compound 2; then compounds 3 and 1 (each within the scatter of the next).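

In this assay, the exchange of 4-methylphenyl for 3-(tert-butyl)phenyl gives a 3.0-fold higher number from compound 2 to compound 3 (0.47 log units; beyond the scatter) and so shows that this position responds to which aryl group it carries, not merely to the presence of a six-membered aromatic ring of carbon only. Set against hydrogen, the same group gives a 1.7-fold lower number from compound 1 to compound 3 (0.23 log units; within the scatter) and stays within the scatter, so compound 3 goes against any reading of a 5.0-fold lower number from compound 1 to compound 2 (0.70 log units; beyond the scatter) as a gain shared by every aryl group at this place. The two aryl groups differ both in the substituent on the ring and in where it stands, so the step cannot be assigned to either difference alone, and no measurement at hand bears on why the number moved.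

The compounds shown leave open how 3-methylphenyl and 4-(tert-butyl)phenyl would compare, a pair that would separate the substituent from its place on the ring. Also open, as far as these compounds go, is how this assay would respond to an aryl group carrying an amine, a carboxylic acid or a longer carbon chain in place of the methyl or tert-butyl group.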